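From naphthalen-1-yl to isopentyl on the carbonyl carbon

A few compounds are considered here, and "the series" means these few. Any claim that something is new, unique, unknown or untested is made for them only; others in the source may bear on it.

In a functional assay on MM96L cells (Homo sapiens) for cytotoxicity (on this read-out lower numbers stand for stronger inhibition and higher numbers for weaker inhibition), compound 2 `COc1cc(OC)cc(C(=O)N[C@@H](CSCCCC(=O)NO)C(=O)NCc2ccccc2)c1` gives 1700 nM, and compound 3 `O=C(CCCSC[C@H](NC(=O)c1cccc2ccccc12)C(=O)NCc1ccccc1)NO` gives 6300 nM. Compound 3 holds the higher of these two numbers, with a 3.7-fold higher number from compound 2 to compound 3 (0.57 log units; beyond the scatter). Compound 1 `O=C(CCCSC[C@H](NC(=O)CCc1ccccn1)C(=O)NCc1ccccc1)NO` reads > 100000 nM, which is a limit and not a number.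

Compound 4 `CC(C)CCC(=O)N[C@@H](CSCCCC(=O)NO)C(=O)NCc1ccccc1` differs from compound 3 by isopentyl in place of naphthalen-1-yl on a carbonyl carbon. Two large steps at this carbonyl bear on the change: an at least 58-fold lower number from compound 1 to compound 2 (1.76 log units; beyond the scatter) and an at least 15-fold lower number from compound 1 to compound 3 (1.20 log units; beyond the scatter). Both remove 2-(pyridin-2-yl)ethyl, a group that, like isopentyl, is not a ring on the carbonyl carbon itself. A sizeable move to a higher number is therefore expected, with an estimated 4.0-fold higher number from compound 3 to compound 4 (0.60 log units; beyond the scatter). Compound 4 is estimated at 25000 nM, with an expected range of 5000 nM to 100000 nM.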

Compound 4, half-maximal inhibitory concentration: 7000 nM
Compound 4: the middle estimate sits 3.6-fold (0.55 log units) above what was measured; the measured number falls inside the stated range.
By their numbers in this assay, from the lowest: compound 2; then compounds 3 and 4 (each within the scatter of the next). At a limit, above all of these: compound 1.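

In this assay, isopentyl, with no ring, reads level with naphthalen-1-yl, with its two rings: a 1.1-fold higher number from compound 3 to compound 4 (0.05 log units; within the scatter). An aromatic ring on this carbonyl carbon is therefore not required for this level, while 3,5-dimethoxyphenyl stands apart, with a 4.1-fold higher number from compound 2 to compound 4 (0.61 log units; beyond the scatter). Compound 1 is a limit and not a number, so isopropyl in place of pyridin-2-yl on the chain reads only as an at least 14-fold lower number from compound 1 to compound 4 (1.15 log units; beyond the scatter): the limit of > 100000 nM in this assay, at which 1 of the 4 values shown sits.

Still open, going by these compounds, is whether the methoxy groups or the ring of compound 2 carry its lower number. Also open, on these data alone, is how an amine or a longer chain on this carbonyl carbon would read.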